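This account rests on a few compounds, and the source may have more. Where it says the series, first, only, none or still open, it means among the compounds named here.

In a functional assay on HCT-116 cells (Homo sapiens) for antiproliferative activity, read by CCK-8 assay, with a stated time of 72 h, tested at 8 uM (a higher number here means a stronger effect of the compound at the concentration tested, a lower number a weaker effect), the measured compounds read as follows:

compound 1 `Nc1ccccc1NC(=O)c1ccc(Cn2cnc3c(Nc4ccccc4)nc(Cl)nc32)cc1`: 83.5%
compound 2 `Nc1ccccc1NC(=O)/C=C/c1ccc(Cn2cnc3c(Nc4cccc(Cl)c4)nc(Cl)nc32)cc1`: 15.8%
compound 3 `Nc1ccccc1NC(=O)/C=C/c1ccc(COCNc2nc(Nc3cccc(Cl)c3)c3ncn(C4CCCC4)c3n2)cc1`: 9.19%

Compound 1 stands highest of the three, with compound 2 and compound 3 both far lower, beyond the scatter. Among the compounds with values here, compounds 2 and 3 differ from compound 1 in several places at once, so no single step between measured compounds is available.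

Compound 4 `Nc1ccccc1NC(=O)c1ccc(Cn2cnc3c(Nc4cccc(OC(F)(F)F)c4)nc(Cl)nc32)cc1` differs from compound 1 in one place: trifluoromethoxy in place of hydrogen on an aromatic carbon, the hydrogen sitting meta to a large group on the anilino ring. Within the data shown here, with no measured step of this kind to lean on, the expected step in this assay from compound 1 is a modest decrease, a number 18.5 percentage points lower from compound 1 to compound 4 (beyond the scatter), though a result within the scatter is possible. Compound 4 is therefore estimated at 65%, within 30% to 90%.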

Compound 4, a percentage reported as inhibition, at one concentration (the size of the read-out at that concentration, not a potency): 46.6%
Compound 4: the middle estimate sits 18.4 percentage points above what was measured, and the stated range covers the measured number.
By their numbers in this assay, from the lowest: compounds 3 and 2 (each within the scatter of the next); then compound 4; then compound 1.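

In this assay, within the data shown here, trifluoromethoxy in place of hydrogen on this aromatic carbon of the anilino ring gives a number 36.9 percentage points lower from compound 1 to compound 4 (beyond the scatter) as the first step confined to one place, so the loss can be tied to this single change. This position of the shared core therefore does not take trifluoromethoxy without a large drop in the read-out. Nothing measured here says why the number falls. Going by these compounds, whether fluorine, methyl or an amine on this carbon would cost as much stays open. So does the outcome of placing trifluoromethoxy on another carbon of the same ring.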